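This account rests on a few compounds, and the source may have more. Where it says the series, first, only, none or still open, it means among the compounds named here.

Working notes on the series in a functional assay on DU-145 cells (Homo sapiens) for cytotoxicity, in the presence of a further agent that is not named here; on this read-out higher numbers stand for weaker inhibition and lower numbers for stronger inhibition.

Of the compounds shown here, three sharing one core have been measured. Compound 1 `Clc1ccc(-c2cc(-c3cccnc3)nc(-c3cccs3)c2)o1` gives 13000 nM in this assay. Compound 2 `Cc1cccc(-c2cc(-c3ccc(Cl)o3)cc(-c3ccsc3)n2)c1` gives 17900 nM, and compound 3 `Cc1ccc(-c2cc(-c3ccoc3)cc(-c3ccsc3)n2)cc1` gives 13000 nM. All three numbers lie within the usual scatter of one another, so none of them can be set apart from the others on these data; compound 2 is simply one of three close values, with compound 1 and compound 3 both near it.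

Compound 4 `Clc1cccc(-c2cc(-c3ccc(Cl)o3)cc(-c3ccsc3)n2)c1` has not yet been measured. It differs from compound 2 in one place: chloro in place of methyl on an aromatic carbon. For the measured compounds named here, no pair of measured compounds in this set differs in the same way, so there is no measured step to lean on for this change.

With only the three close values of compound 1, compound 2 and compound 3 to go by, the expected step of a 1.2-fold lower number from compound 2 to compound 4 (0.08 log units; within the scatter) is none beyond the scatter. Compound 4 is therefore estimated at 15000 nM, with a range from 6000 nM to 40000 nM.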

Compound 4, half-maximal inhibitory concentration: 10400 nM
Compound 4: the middle estimate sits 1.4-fold (0.16 log units) above what was measured; the measured number falls inside the stated range.
By their numbers in this assay, from the lowest: compounds 4, 1, 3 and 2 (each within the scatter of the next).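

The series now holds one measured step: in this assay, chloro in place of methyl on an aromatic carbon, read one bond further out as 3-methylphenyl to 3-chlorophenyl, gives a 1.7-fold lower number from compound 2 to compound 4 (0.24 log units; within the scatter). For the compounds shown here, the earlier compounds offered no pair differing in one place, so this is the only direct reading at this position, and on it compound 2 and compound 4 cannot be set apart. No supporting data bear on this result, which therefore rests on the two numbers alone.

As far as these compounds go, whether an amine, a carboxylic acid or a longer chain at this position of the six-membered ring would move the number beyond the scatter remains open. Also open, from the compounds shown here alone, is whether the same exchange would read alike with other groups on the shared core, since the step rests on a single pair.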